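A few compounds are considered here, and "the series" means these few. Any claim that something is new, unique, unknown or untested is made for them only; others in the source may bear on it.

Measured compounds in a functional assay on Jurkat cells (Homo sapiens) for cytotoxicity, read by MTT assay, with a stated time of 24 h; on this read-out higher numbers stand for an effect only at larger amounts of compound and lower numbers for an effect already at smaller amounts:
Compound 1 `CCOC(=O)c1cc([Se]c2ccccc2C)c2cc(OC)ccc2n1` gives 14900 nM.
Compound 2 `CCOC(=O)c1cc(C#Cc2ccc(N)cc2)c2cc(OC)ccc2n1` gives 61000 nM.
Compound 3 `CCOC(=O)c1cc([Se]c2ccc3ccccc3c2)c2cc(OC)ccc2n1` gives 50700 nM.

Compound 3 holds the second highest of the three numbers in this assay. Its nearest neighbour is compound 2, whose value sits within the usual scatter of that of compound 3, so no order between the two can be read; compound 1 stands furthest away, with a lower number that lies beyond the scatter. Compound 4 `CCOC(=O)c1cc([Se]c2ccc3cc(OC)ccc3c2)c2cc(OC)ccc2n1` differs from compound 3 by methoxy in place of hydrogen on an aromatic carbon. Within the data shown here, no pair of measured compounds differing in one place is available, so nothing shows how such a change acts here. For compound 4 a step no larger than the scatter is expected, in no clear direction, a 1.0-fold lower number from compound 3 to compound 4 (0.01 log units; within the scatter). Compound 4 is therefore estimated at 50000 nM, within the range 15000 nM to 150000 nM.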

Compound 4, half-maximal effective concentration: 31300 nM
The estimate for compound 4 lay 1.6-fold (0.20 log units) above the measured number; the range from low to high includes it.
By their numbers in this assay, from the lowest: compound 1; then compounds 4, 3 and 2 (each within the scatter of the next).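

In this assay, among these compounds, methoxy in place of hydrogen on an aromatic carbon, meta to a fused ring and para to a fused ring, brings a 1.6-fold lower number from compound 3 to compound 4 (0.21 log units; within the scatter) and so gives the first comparison of compounds differing in one place. This step stays within the scatter, so the change shows no clear effect at this position. Nothing measured alongside these numbers speaks to what lies behind this result. Going by these compounds, whether an amine, a carboxylic acid or a longer chain at this position would move the number beyond the scatter remains open.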